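Compound 3 to compound 4: replacing the oxetan-3-yl group

The compounds below may be only part of what the source reports. "The series", "measured", "known", "first", "only" and "open" are said of these compounds alone.

Compounds measured in a functional assay on HeLa cells (Homo sapiens) for antiproliferative activity, read by MTT assay, with a stated time of 48 h (on this read-out higher numbers stand for weaker inhibition and lower numbers for stronger inhibition), so far:
compound 1 `CCOc1cc(-c2ccc3[nH]ccc3c2)cn2c(-c3cc(OC)c(OC)c(OC)c3)nnc12` with 166 nM
compound 2 `COc1cc(-c2nnc3c(OC(C)C)cc(-c4ccc5[nH]ccc5c4)cn23)cc(OC)c1OC` with 261 nM
compound 3 `COc1cc(-c2nnc3c(OC4COC4)cc(-c4ccc5[nH]ccc5c4)cn23)cc(OC)c1OC` with 2780 nM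

Compound 3 has the highest number of the three in this assay and is therefore the weakest inhibitor here. Compound 4 `COc1cc(-c2nnc3c(OCC(F)(F)F)cc(-c4ccc5[nH]ccc5c4)cn23)cc(OC)c1OC` has not been measured yet. It keeps the shared core but carries 2,2,2-trifluoroethyl in place of oxetan-3-yl on an oxygen on an aromatic ring.

For the measured compounds named here, three measured steps bear on this change. Going from ethyl to isopropyl on that oxygen made little difference (a 1.6-fold higher number from compound 1 to compound 2 (0.20 log units; within the scatter)). Oxetan-3-yl in place of either chain gave large steps (a 17-fold higher number from compound 1 to compound 3 (1.22 log units; beyond the scatter); an 11-fold higher number from compound 2 to compound 3 (1.03 log units; beyond the scatter)). Like ethyl and isopropyl, 2,2,2-trifluoroethyl has no ring, although no fluorinated compound has been measured. A large drop in the number is therefore expected (a 7.9-fold lower number from compound 3 to compound 4 (0.90 log units; beyond the scatter)). For compound 4 the estimated value is 350 nM (expected range 110 nM to 1100 nM).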

Compound 4, half-maximal inhibitory concentration: 348 nM
The estimate for compound 4 lay 1.0-fold (0.00 log units) above the measured number; the range from low to high includes it.
By their numbers in this assay, from the lowest: compounds 1, 2 and 4 (each within the scatter of the next, the first and the last beyond it); then compound 3.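

In this assay, a group without a ring, 2,2,2-trifluoroethyl, restores most of what oxetan-3-yl gave up on this oxygen, with an 8.0-fold lower number from compound 3 to compound 4 (0.90 log units; beyond the scatter). Fluorine on the chain is largely accepted at this position: trading isopropyl for 2,2,2-trifluoroethyl gives a 1.3-fold higher number from compound 2 to compound 4 (0.12 log units; within the scatter), while trifluoromethyl in place of methyl on the ethyl chain carries only a modest cost, with a 2.1-fold higher number from compound 1 to compound 4 (0.32 log units; beyond the scatter). Nothing measured here gives a reason for these differences.

Oxetan-3-yl is the only group with a ring on this oxygen, so the compounds shown cannot separate the effect of the ring from that of the oxygen inside it. On these data alone, how cyclobutyl, a ring without that oxygen, or 2-methoxyethyl, a chain with an oxygen but no ring, would read in this assay stays open.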